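The source may hold more compounds than are shown below. What is called first, only, known or untested is meant among the compounds shown, and "the series" means these compounds.

Working notes on the series. Compound 1 `Cc1cc(=O)n(-c2ccccc2OC(F)(F)F)nc1C(=O)Nc1ccc(Oc2ncnc3ccsc23)cc1` gives 10100 nM in a functional assay on A549 cells (Homo sapiens) for cytotoxicity, read by MTT assay, with a stated time of 72 h; on this read-out higher numbers stand for weaker inhibition and lower numbers for stronger inhibition. Compound 2 `Cc1cc(=O)n(-c2cccc(F)c2)nc1C(=O)Nc1ccc(Oc2ncnc3ccsc23)cc1` gives 9540 nM in this assay. The change from compound 1 to compound 2 is 3-fluorophenyl in place of 2-(trifluoromethoxy)phenyl on an aromatic nitrogen, and it made a step of a 1.1-fold lower number from compound 1 to compound 2 (0.02 log units; within the scatter). Compound 3 `Cc1cc(=O)n(-c2ccccc2OC(F)(F)F)nc1C(=O)Nc1ccc(Oc2ncnc3sccc23)c(F)c1` is reported in this assay only as a limit, > 40000 nM, which is the limit of > 40000 nM in this assay, at which 1 of the 3 values shown sits. The difference between the core of compound 1 and the core of compound 3 is not broken down here. Compound 4 `Cc1cc(=O)n(-c2cccc(F)c2)nc1C(=O)Nc1ccc(Oc2ncnc3sccc23)c(F)c1` carries, relative to compound 3, the same change: 3-fluorophenyl in place of 2-(trifluoromethoxy)phenyl on an aromatic nitrogen. The step from compound 3 to compound 4 in this assay is expected to be small, a number no higher from compound 3 to compound 4 (the limit leaves the size open), because the same change gave a 1.1-fold lower number from compound 1 to compound 2 (0.02 log units; within the scatter). Compound 4 is therefore estimated at 40000 nM, expected between 18000 nM and 90000 nM. A limit rather than a number is the likelier report.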

Compound 4, half-maximal inhibitory concentration: 19500 nM
Compound 4: the middle estimate sits 2.1-fold (0.31 log units) above what was measured; the measured number falls inside the stated range.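

Compound 3 stands in this assay only as a limit, > 40000 nM. On the core of compound 3, 3-fluorophenyl in place of 2-(trifluoromethoxy)phenyl gives an at least 2.0-fold lower number from compound 3 to compound 4 (0.31 log units; beyond the scatter). Carried to this second core, the change does not raise the number, but the data do not show whether its size carries over from the core of compound 1: the same change on two cores in this assay, a 1.1-fold lower number (0.02 log units; within the scatter) from compound 1 to compound 2 and an at least 2.0-fold lower number (0.31 log units; beyond the scatter) from compound 3 to compound 4; the limit leaves it open whether they differ

The compounds shown leave open how the two cores would compare with any other group on the aromatic nitrogen, such as a plain phenyl, a short alkyl chain or a phenyl bearing an amine or a carboxylic acid. They also leave open what each difference between the two cores contributes on its own.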